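A few compounds are considered here, and "the series" means these few. Any claim that something is new, unique, unknown or untested is made for them only; others in the source may bear on it.

In a functional assay on HeLa cells (Homo sapiens) for inhibition, read by sulforhodamine B assay (a higher number here means a weaker inhibitor, a lower number a stronger inhibitor), compound 1 `O=C1C=C(N2CCC2)C(=O)c2c1nc1n2[C@H]2OC[C@@H](O)[C@H]2OC1` reports only a limit, > 16000 nM. Compound 2 `COc1ccccc1NC1=CC(=O)c2nc3n(c2C1=O)[C@H]1OC[C@@H](O)[C@H]1OC3` gives 2950 nM, and compound 3 `CCOc1ccccc1NC1=CC(=O)c2nc3n(c2C1=O)[C@H]1OC[C@@H](O)[C@H]1OC3` gives 6040 nM, the higher of the two actual numbers. Compound 4 `Cc1ccc(NC2=CC(=O)c3nc4n(c3C2=O)[C@H]2OC[C@@H](O)[C@H]2OC4)cc1C` has 3,4-dimethylphenyl in place of 2-ethoxyphenyl on an amine nitrogen. Among the compounds with values here, two measured steps bear on this change. The broader one, (2-methoxyphenyl)amino in place of azetidin-1-yl, gave an at least 5.4-fold lower number from compound 1 to compound 2 (0.73 log units; beyond the scatter). The closer one, methyl in place of hydrogen on the alkoxy chain, gave the modest 2.0-fold higher number from compound 2 to compound 3 (0.31 log units; beyond the scatter). Neither step tests 3,4-dimethylphenyl directly, so only a modest change towards a lower number is expected in this assay. The expected step is a 1.7-fold lower number from compound 3 to compound 4 (0.24 log units; within the scatter). Compound 4 is estimated at 3500 nM, within an expected range of 1000 nM to 12000 nM.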

Compound 4, half-maximal inhibitory concentration: 2690 nM
Compound 4: middle estimate off by 1.3-fold (0.11 log units), on the high side; measured number inside the range.
By their numbers in this assay, from the lowest: compounds 4 and 2 (each within the scatter of the next); then compound 3. At a limit, above all of these: compound 1.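

In this assay, 3,4-dimethylphenyl, which has no oxygen, sits on the amine nitrogen with a 1.1-fold lower number from compound 2 to compound 4 (0.04 log units; within the scatter) against 2-methoxyphenyl, so an alkoxy group is not needed here for this level of inhibition. The ethoxy compound is the one that stands apart, given a 2.2-fold lower number from compound 3 to compound 4 (0.35 log units; beyond the scatter) and the printed gap to the dimethyl compound. Exchanging azetidin-1-yl for (3,4-dimethylphenyl)amino gives an at least 5.9-fold lower number from compound 1 to compound 4 (0.77 log units; beyond the scatter) and starts from a value that is only a limit: the limit of > 16000 nM in this assay, at which 1 of the 4 values shown sits.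

As far as these compounds go, whether a chloro group or a carboxylic acid on the phenyl ring would hold this level stays open. So does the effect of a longer alkyl chain on the amine nitrogen in place of the aryl group.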